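Replacing cyanosulfanyl with 1-chloroethenyl on the shared core

A few compounds are considered here, and "the series" means these few. Any claim that something is new, unique, unknown or untested is made for them only; others in the source may bear on it.

Within the data shown here, in an ADME assay on L1210/0 cells (Mus musculus) for cytotoxicity, with a stated time of 48 h (a lower number here means a stronger inhibitor, a higher number a weaker inhibitor), compound 2 (`N#CSc1cn([C@H]2C[C@H](O)[C@@H](CO)O2)c(=O)[nH]c1=O`) gives 78900 nM as the higher of the two numbers so far, and compound 1 (`O=c1[nH]c(=O)n([C@H]2C[C@H](O)[C@@H](CO)O2)cc1CO`) gives 9180 nM as the lower. Compound 3 (`C=C(Cl)c1cn([C@H]2C[C@H](O)[C@@H](CO)O2)c(=O)[nH]c1=O`) carries 1-chloroethenyl in place of cyanosulfanyl on an aromatic carbon. Among the measured compounds shown here, the one measured step at this place is an 8.6-fold higher number from compound 1 to compound 2 (0.93 log units; beyond the scatter) and it is modest, though it does not test the new group. For the measured compounds named here, with compound 2 high at 78900 nM and that step as the only guide, a modest fall is expected. The estimated step is a 2.0-fold lower number from compound 2 to compound 3 (0.30 log units; within the scatter) and it remains uncertain. In this assay the estimated value for compound 3 is 40000 nM (from 7000 nM to 200000 nM).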

Compound 3, half-maximal inhibitory concentration: 1660 nM
Estimate against measurement, compound 3: 24-fold (1.38 log units) above, and the stated range ends above it.
By their numbers in this assay, from the lowest: compound 3; then compound 1; then compound 2.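

In this assay, among these compounds, 1-chloroethenyl gives the lowest number so far at this position, with a 48-fold lower number from compound 2 to compound 3 (1.68 log units; beyond the scatter) and a 5.5-fold lower number from compound 1 to compound 3 (0.74 log units; beyond the scatter). The group on this aromatic carbon can therefore shift the number in either direction, even when cyanosulfanyl and 1-chloroethenyl have the same heavy-atom count. Nothing available explains the difference between these groups. As far as these compounds go, it remains open whether the chlorine or the double bond matters more, which plain ethenyl would help to separate. An amine or a carboxylic acid at this position also remains to be compared.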